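The source may report more compounds than this note shows. Statements on the series, on what has been measured and on what is new or still open speak of the compounds shown alone.

Working notes on the series. Compounds 1 and 2 share a dione core; compound 1 `COc1ccc(CN2C(=O)C(=O)c3cc(-c4ccc(F)cc4)ccc32)cc1` gives 240 nM in a functional assay on K562 cells (Homo sapiens) for antiproliferative activity, read by MTT assay, with a stated time of 48 h (a higher number here means a weaker inhibitor, a lower number a stronger inhibitor), and compound 2 `COc1ccc(CN2C(=O)C(=O)c3cc(-c4ccc(OC(C)C)cc4)ccc32)cc1` gives 310 nM. Among the measured compounds shown here, the only single-point step measured so far, a 1.3-fold higher number from compound 1 to compound 2 (0.11 log units; within the scatter), is small. Compound 3 `COC(=O)/C=C1\C(=O)N(Cc2ccc(OC)cc2)c2ccc(-c3ccc(OC)cc3)cc21`, which carries an exocyclic methoxycarbonyl-bearing double bond instead of the second carbonyl, gives 1900 nM in this assay, the highest of the three numbers; compound 2 is nearest and compound 1 furthest, both gaps being beyond the scatter.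

The step under consideration goes from compound 3 to compound 4 `COc1ccc(CN2C(=O)/C(=C\c3ccc(C(C)C)cc3)c3cc(-c4ccc(OC)cc4)ccc32)cc1`: 4-isopropylphenyl in place of methoxycarbonyl on a double-bonded chain carbon bound to a double-bonded ring carbon. For the measured compounds named here, no measured step bears on this change. Going by the values given here, the one step at hand, from compound 1 to compound 2, concerns a substituent on the distal aromatic ring and a different core, and so carries no information about swapping the group on the exocyclic double bond. Among the compounds with values here, the gap between compound 3 and compounds 1 and 2 shows only that the dione core gives lower numbers than the methoxycarbonyl alkylidene core.

Within the data shown here, with no precedent, the expected step of a 2.1-fold lower number from compound 3 to compound 4 (0.32 log units; beyond the scatter) is set near the scatter with a wide range. Compound 4 is estimated at 900 nM, expected between 250 nM and 3500 nM in this assay.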

Compound 4, half-maximal inhibitory concentration: > 10000 nM
Compound 4 gave a limit, no number (the forecaster's own chance of this, stated with the estimate: 5%); at least 11-fold (1.04 log units) between middle value and limit.
By their numbers in this assay, from the lowest: compounds 1 and 2 (each within the scatter of the next); then compound 3. At a limit, above all of these: compound 4.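

Compound 4 gives only a limit in this assay, > 10000 nM, and not a number. Among the compounds shown here, with 4-isopropylphenyl in place of methoxycarbonyl on a double-bonded chain carbon bound to a double-bonded ring carbon, the result is an at least 5.2-fold higher number from compound 3 to compound 4 (0.72 log units; beyond the scatter), so the group at this position matters in this assay, whereas the only earlier step, a 1.3-fold higher number from compound 1 to compound 2 (0.11 log units; within the scatter), lay within the scatter and concerned another place. The step is a bound whose full size cannot be read, and it rests on a single limit value: the limit of > 10000 nM in this assay, at which 1 of the 4 values shown sits.

The compounds shown leave open whether the change in the number goes with the aromatic ring itself, with the isopropyl on it, or with the loss of the methoxycarbonyl group's ester function. An unsubstituted phenyl, a pyridine ring, a carboxylic acid or a primary amide on the same carbon would begin to separate these readings, as would a methyl ester on a longer chain.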